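The compounds below may be only part of what the source reports. "The series", "measured", "known", "first", "only" and "open" are said of these compounds alone.

In a functional assay, with a stated time of 30 min (a higher number here means a weaker inhibitor, a lower number a stronger inhibitor), compound 1 `CCCCc1oc2ccc(/N=C/c3ccc(O)cc3)cc2c1C(=O)c1ccc(OC)cc1` gives 22.8 ug/mL, at the low end of the three numbers and level with compound 2 `CCCCc1oc2ccc(/N=C/c3ccc(C#N)cc3)cc2c1C(=O)c1ccc(OC)cc1` at 27.2 ug/mL. Compound 3 `CCCCc1oc2ccc(/N=C/c3ccc(F)cc3)cc2c1C(=O)c1ccc(OC)cc1` gives 100 ug/mL. The step to compound 4 `CCCCc1oc2ccc(/N=C/c3ccc(OC)cc3OC)cc2c1C(=O)c1ccc(OC)cc1`, not yet measured, is 2,4-dimethoxyphenyl in place of 4-hydroxyphenyl on a carbon with a double bond to nitrogen.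

Among the compounds with values here, no measured compound carries this group, so the bearing steps are only indirect. Two of them replace the hydroxy: cyano gives a 1.2-fold higher number from compound 1 to compound 2 (0.08 log units; within the scatter), and fluoro gives a 4.4-fold higher number from compound 1 to compound 3 (0.64 log units; beyond the scatter). The third step, a 3.7-fold higher number from compound 2 to compound 3 (0.57 log units; beyond the scatter), shows that the number moves with the group on this ring. Since neither replacement of the hydroxy in compound 1 brought a step to a lower number beyond the scatter, a modest move to a higher number is expected, though a result within the scatter remains possible. The expected step is a 2.0-fold higher number from compound 1 to compound 4 (0.30 log units; within the scatter). For compound 4 the estimate is 45 ug/mL, with an expected range of 20 ug/mL to 100 ug/mL.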

Compound 4, half-maximal inhibitory concentration: 20.5 ug/mL
Compound 4: the middle estimate sits 2.2-fold (0.34 log units) above what was measured, and the stated range covers the measured number.
By their numbers in this assay, from the lowest: compounds 4, 1 and 2 (each within the scatter of the next); then compound 3.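

In this assay, 2,4-dimethoxyphenyl on a carbon with a double bond to nitrogen stays level with 4-hydroxyphenyl, a 1.1-fold lower number from compound 1 to compound 4 (0.05 log units; within the scatter), and with 4-cyanophenyl, a 1.3-fold lower number from compound 2 to compound 4 (0.12 log units; within the scatter), so this place accepts a group of 10 heavy atoms with 0 hydrogen-bond donors in place of one of 7 heavy atoms with 1 donor. The 4-fluorophenyl group now stands alone among the four, a 4.9-fold lower number from compound 3 to compound 4 (0.69 log units; beyond the scatter), which makes compound 3 the only one apart from an otherwise level set. No measurement at hand accounts for this flat response or for the position of compound 3.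

The compounds shown do not separate the contributions of the two methoxy groups, which a phenyl carrying a single methoxy could address. Going by these compounds, it also remains open whether an amine or a carboxylic acid on this ring would bring a number beyond the scatter below that of compound 1.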